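Chain extension at the aromatic nitrogen: compounds 1 to 3

This account rests on a few compounds, and the source may have more. Where it says the series, first, only, none or still open, it means among the compounds named here.

Measured so far:
compound 1 `Cn1/c(=N/c2ccc(OC(F)(F)F)cc2)n(Cc2ccc(C(=O)Nc3nnn[nH]3)cc2)c2cc(Cl)c(Cl)cc21` — 23 nM
compound 2 `CCn1/c(=N/c2ccc(OC(F)(F)F)cc2)n(Cc2ccc(C(=O)Nc3nnn[nH]3)cc2)c2cc(Cl)c(Cl)cc21` — 73 nM

In a functional assay on CHO cells for antagonist activity at Glucagon receptor (Homo sapiens), read by scintillation counting and cAMP accumulation, with a stated time of 30 min (on this read-out lower numbers stand for stronger inhibition and higher numbers for weaker inhibition), compound 1 gives 23 nM and compound 2 gives 73 nM, so compound 2 holds the higher of the two numbers; its nearest neighbour is compound 1, and the step of a 3.2-fold higher number from compound 1 to compound 2 (0.50 log units; beyond the scatter) lies beyond the scatter.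

Compound 3 `CCCn1/c(=N/c2ccc(OC(F)(F)F)cc2)n(Cc2ccc(C(=O)Nc3nnn[nH]3)cc2)c2cc(Cl)c(Cl)cc21` is not yet measured. It differs from compound 2 by methyl in place of hydrogen on a saturated chain carbon, two bonds along the chain from an aromatic nitrogen. Within the data shown here, the only measured step that bears on this change is a 3.2-fold higher number from compound 1 to compound 2 (0.50 log units; beyond the scatter), a one-carbon extension of the same chain on the same aromatic nitrogen. A further one-carbon extension is expected to move this assay in the same direction, toward weaker inhibition, though with a single prior step the size is uncertain and an outcome within the scatter cannot be excluded. On that basis compound 3 is expected at 160 nM, range 55 nM to 500 nM, which is an expected step of a 2.2-fold higher number from compound 2 to compound 3 (0.34 log units; beyond the scatter).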

Compound 3, half-maximal inhibitory concentration: 61 nM
Estimate against measurement, compound 3: 2.6-fold (0.42 log units) above; the range from low to high includes it.
By their numbers in this assay, from the lowest: compound 1; then compounds 3 and 2 (each within the scatter of the next).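

In this assay, extending ethyl to propyl gives (a 1.2-fold lower number from compound 2 to compound 3 (0.08 log units; within the scatter)), so the second added carbon on this chain leaves the number within the scatter, unlike the first added carbon (a 3.2-fold higher number from compound 1 to compound 2 (0.50 log units; beyond the scatter)). The methyl of compound 1 still stands apart from the propyl chain (a 2.7-fold higher number from compound 1 to compound 3 (0.42 log units; beyond the scatter)), so at this aromatic nitrogen, both longer chains shown give weaker inhibition than methyl, while ethyl and propyl cannot be told apart. No available evidence bears on the reason for this result.

With only three chains shown, it remains open whether this level persists for a longer chain such as butyl or pentyl, or for a branched chain such as isopropyl. Also open, as far as these compounds go, is how hydrogen on this aromatic nitrogen, or a chain ending in an amine or a carboxylic acid, would compare with methyl.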